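Amide aryl variation on the shared triazole-thioacetamide core

This account rests on a few compounds, and the source may have more. Where it says the series, first, only, none or still open, it means among the compounds named here.

Compound 1 `Cc1cccc(C)c1NC(=O)CSc1nnc(-c2ccoc2C)n1Cc1ccco1` carries a 2,6-dimethylphenyl on the amide-type nitrogen of the shared core. In a functional assay on CHO cells for antagonist activity at Orexin receptor type 2 (Homo sapiens), read by FLIPR and calcium flux (a lower number here means a stronger inhibitor, a higher number a weaker inhibitor), compound 1 gives > 15800 nM, which is a limit of the assay and not a number. Compound 2 `Cc1cccc(NC(=O)CSc2nnc(-c3ccoc3C)n2Cc2ccco2)c1C` likewise gives > 15800 nM, again only a limit. Compound 3 `COc1ccc(NC(=O)CSc2nnc(-c3ccoc3C)n2Cc2ccco2)cc1` gives 200 nM, and the steps of an at least 79-fold lower number from compound 1 to compound 3 (1.89 log units; beyond the scatter) and an at least 79-fold lower number from compound 2 to compound 3 (1.89 log units; beyond the scatter) are both large, whereas a step that the two limits leave unreadable from compound 1 to compound 2 cannot be read because both values sit at the limit of > 15800 nM in this assay, at which 2 of the 3 values shown sit. Compound 4 `CC(=O)c1cccc(NC(=O)CSc2nnc(-c3ccoc3C)n2Cc2ccco2)c1` introduces the change (3-acetylphenyl in place of 2,6-dimethylphenyl on an amide-type nitrogen). Going by the values given here, only the step to compound 3 bears on it, and it points toward a markedly lower number, though the 3-acetylphenyl is not the 4-methoxyphenyl, so the size is uncertain. Compound 4 is expected to give about 1500 nM, within 200 nM to 15800 nM. The expected step is an at least 10-fold lower number from compound 1 to compound 4 (1.02 log units; beyond the scatter).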

Compound 4, inhibition constant: 316 nM
Beside the measured number, compound 4's estimate is 4.7-fold (0.68 log units) above it; the measured number falls inside the stated range.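

In this assay, the step of a 1.6-fold higher number from compound 3 to compound 4 (0.20 log units; within the scatter) shows that a low number on this amide-type nitrogen is not confined to the 4-methoxyphenyl. The 3-acetylphenyl also separates from both dimethylphenyl compounds, with an at least 50-fold lower number from compound 1 to compound 4 (1.69 log units; beyond the scatter) and an at least 50-fold lower number from compound 2 to compound 4 (1.69 log units; beyond the scatter) as the two steps. Both sizes are bounds only: the limit of > 15800 nM in this assay, at which 2 of the 4 values shown sit.

Which feature of the 3-acetylphenyl and the 4-methoxyphenyl sets them apart from the dimethylphenyl groups remains unsettled. Going by these compounds, what an unsubstituted phenyl, or an amine or a carboxylic acid in place of the acetyl, would give also stays open.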